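A few compounds are considered here, and "the series" means these few. Any claim that something is new, unique, unknown or untested is made for them only; others in the source may bear on it.

Measured compounds:
compound 1, `COc1ccc(-c2cc(/C=C/C(=O)c3ccc(N)cc3)[nH]n2)cc1`: 5410 nM
compound 2, `COc1cc(-c2cc(/C=C/C(=O)c3ccc(N)cc3)[nH]n2)cc(OC)c1OC`: 6370 nM

Of the compounds shown here, two have been tested in a functional assay on SW-620 cells (Homo sapiens) for inhibition, read by sulforhodamine B assay, with a stated time of 48 h; on this read-out lower numbers stand for stronger inhibition of growth and higher numbers for weaker inhibition of growth. Compound 1, `COc1ccc(-c2cc(/C=C/C(=O)c3ccc(N)cc3)[nH]n2)cc1`, gives 5410 nM. Compound 2, `COc1cc(-c2cc(/C=C/C(=O)c3ccc(N)cc3)[nH]n2)cc(OC)c1OC`, gives 6370 nM. These two numbers lie within the usual scatter of each other, so neither compound can be set apart from the other on this read-out. Compound 3, `COc1cc(-c2cc(/C=C/C(=O)c3ccc(Cl)c(Cl)c3)[nH]n2)cc(OC)c1OC`, has not yet been measured. Compared with compound 2 it carries 3,4-dichlorophenyl in place of 4-aminophenyl on a carbonyl carbon. Within the data shown here, no measured pair shows what such a swap does on this read-out, so there is no basis for expecting a step beyond the scatter in either direction. The expectation for compound 3 in this assay is therefore a number close to that of compound 2, a step of a 1.1-fold lower number from compound 2 to compound 3 (0.03 log units; within the scatter). Compound 3 is thus estimated at 6000 nM, with a range from 2000 nM to 18000 nM.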

Compound 3, concentration for total growth inhibition: 79600 nM
Beside the measured number, compound 3's estimate is 13-fold (1.12 log units) below it; measured number outside the range, above it.
By their numbers in this assay, from the lowest: compounds 1 and 2 (each within the scatter of the next); then compound 3.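

In this assay, putting 3,4-dichlorophenyl in place of 4-aminophenyl on the carbonyl carbon gives a 12-fold higher number from compound 2 to compound 3 (1.10 log units; beyond the scatter), so growth inhibition is weaker and this position clearly matters, which compounds 1 and 2 could not show because they differ elsewhere. The change is not a single one: the group that leaves holds nitrogen and counts a hydrogen-bond donor and acceptor, while the group that enters holds chlorine and counts neither. No measurement here explains why the number rises.

Still open, going by these compounds, is whether the step follows the removal of the amine or the arrival of the chlorines, which a plain phenyl or a 4-chlorophenyl at this place could help separate. Also open, on these data alone, is whether the same swap has a similar effect on the core of compound 1.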